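Dropping the drawn configuration: compound 1 to compound 3

The source may report more compounds than this note shows. Statements on the series, on what has been measured and on what is new or still open speak of the compounds shown alone.

Measured so far:
compound 1 `CC(=O)OC[C@@H]1CN(C(C)=O)CCN1S(=O)(=O)c1ccc(F)cc1`: 1 mg/kg
compound 2 `CCOC(=O)C1CN(S(=O)(=O)c2ccc(F)cc2)CCN1C(C)=O`: 1 mg/kg

In a functional assay on the whole organism (strain CD-1) with Mus musculus as the target, with a stated time of 20 min (on this read-out higher numbers stand for an effect only at larger amounts of compound and lower numbers for an effect already at smaller amounts), compound 1 gives 1 mg/kg, level at the digits shown with compound 2, which gives 1 mg/kg; the two sit within the scatter. Within the data shown here, compound 3 `CC(=O)OCC1CN(C(C)=O)CCN1S(=O)(=O)c1ccc(F)cc1` is still to be measured in this assay. the two compounds have the same atoms and bonds; at least one stereo element is drawn with a configuration in one of them and without one in the other: 1 of 1 stereo elements differ; a stereocentre at a saturated ring carbon is drawn S in compound 1 and without a configuration in compound 3 No measured pair shows this kind of change, so the step is expected to be none beyond the scatter, perhaps a slight shift toward larger amounts. Compound 3 is therefore expected at 1.3 mg/kg, with a range of 0.6 mg/kg to 3 mg/kg. The estimated step of a 1.3-fold higher number from compound 1 to compound 3 (0.11 log units; within the scatter) lies within the scatter.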

Compound 3, minimum effective dose: 0.1 mg/kg
Compound 3: the middle estimate sits 13-fold (1.11 log units) above what was measured; the whole stated range lies above it.
By their numbers in this assay, from the lowest: compound 3; then compounds 1 and 2 (each within the scatter of the next).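

In this assay, the stereocentre at the saturated ring carbon emerges as a sensitive point, which the level pair of compound 1 and compound 2 did not reveal: a 10-fold lower number from compound 1 to compound 3 (1.00 log units; beyond the scatter). With atoms and bonds identical, the structures offer only one difference to attach this step to: the fact that one of compounds 1 and 3 is drawn with a defined configuration and the other without, at the place where they differ

Open, going by these compounds, is how a form drawn with the opposite configuration would read out, since the drawing of compound 3 does not state its composition at this centre. Also open, on these data alone, is whether the step would persist with an amine or a carboxylic acid in place of the acetate ester.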